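The source may hold more compounds than are shown below. What is called first, only, known or untested is meant among the compounds shown, and "the series" means these compounds.

In a functional assay on NCI-H1975 cells (Homo sapiens) for cytotoxicity, read by MTT assay, with a stated time of 72 h (a lower number here means a stronger inhibitor, a higher number a weaker inhibitor), compound 1 (`COc1cc(/C=C2\CNC/C(=C\c3cc(OC)c(OC)c(OC)c3)C2=O)cc(OC)c1OC`) gives 4000 nM and compound 2 (`CCN1C/C(=C\c2cc(OC)c(OC)c(OC)c2)C(=O)/C(=C/c2cc(OC)c(OC)c(OC)c2)C1`) gives 6500 nM. Ethyl on the amine nitrogen in the ring therefore changes little, with a 1.6-fold higher number from compound 1 to compound 2 (0.21 log units; within the scatter). Compound 3 (`COc1cc(/C=C2\CN(C(=O)CCC(=O)O)C/C(=C\c3cc(OC)c(OC)c(OC)c3)C2=O)cc(OC)c1OC`) is reported only as a limit, > 60000 nM. Its (2-carboxyethyl)carbonyl on the same nitrogen marks the two clear steps of the series, an at least 15-fold higher number from compound 1 to compound 3 (1.17 log units; beyond the scatter) and an at least 9.2-fold higher number from compound 2 to compound 3 (0.96 log units; beyond the scatter).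

Compound 4 (`COc1cc(/C=C2\CN(C(=O)C(C)C)C/C(=C\c3cc(OC)c(OC)c(OC)c3)C2=O)cc(OC)c1OC`) has isopropyl in place of 2-carboxyethyl on a carbonyl carbon. Within the data shown here, no measured step makes this exact change, and no measured compound carries isopropylcarbonyl. The closest evidence is the pair of steps into compound 3, so removing 2-carboxyethyl should reverse at least part of an at least 15-fold higher number from compound 1 to compound 3 (1.17 log units; beyond the scatter). A move to a lower number in this assay, of modest to large size, is therefore expected. The estimate means an at least 15-fold lower number from compound 3 to compound 4 (1.17 log units; beyond the scatter). Compound 4 is expected at 4000 nM, within an estimated range from 700 nM to 25000 nM.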

Compound 4, half-maximal inhibitory concentration: 1900 nM
For compound 4 the middle estimate is 2.1-fold (0.32 log units) above the measured one; low and high end bracket the measured number.
By their numbers in this assay, from the lowest: compound 4; then compounds 1 and 2 (each within the scatter of the next). At a limit, above all of these: compound 3.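

In this assay the change gives an at least 31-fold lower number from compound 3 to compound 4 (1.49 log units; beyond the scatter) and so separates the two parts of the earlier substituent: a carbonyl on the ring nitrogen is compatible with activity, and the loss at compound 3 goes with the 2-carboxyethyl and not with the carbonyl alone. Among these compounds, with a 3.4-fold lower number from compound 2 to compound 4 (0.53 log units; beyond the scatter) and a 2.1-fold lower number from compound 1 to compound 4 (0.32 log units; beyond the scatter) the isopropylcarbonyl also gives a lower number than either ethyl or hydrogen on that nitrogen, which the earlier compounds, all level or worse, did not show. Compound 3 stands only at a limit, so the first of these steps has no upper end: the limit of > 60000 nM in this assay, at which 1 of the 4 values shown sits.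

On these data alone, whether a longer alkyl chain, a phenyl ring or an amine on the carbonyl carbon would hold or extend this gain remains open. Also open, as far as these compounds go, is whether the carboxylic acid or its chain goes with the loss, a question that the methyl ester of the same chain would address.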